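The compounds below may be only part of what the source reports. "The series", "measured", "known", "first", "only" and "open" are said of these compounds alone.

Compound 2 `NC(=O)C[C@H](NC(=O)CN(c1ncnc2c1ncn2C1CCCCO1)C1CC1)C(=O)OCc1ccccc1` gives 35% in a functional assay on the whole organism (Tail, strain ICR) with Mus musculus as the target, in the tail flick test, with a stated time of 90 min, at a dose of 25 umol/kg by the oral route (on this read-out lower numbers stand for a weaker effect and higher numbers for a stronger effect at the one dose given), the second highest of the three numbers. Compound 1 `O=C(O)CC[C@H](NC(=O)CN(c1nc(Cl)nc2[nH]cnc12)C1CC1)C(=O)O` gives 44.7% and compound 3 `NCCCC[C@H](NC(=O)CN(c1nc(Cl)nc2[nH]cnc12)C1CC1)C(=O)O` gives 28.8%; compound 2 lies within the scatter of both. Compound 4 `CC(C)[C@H](NC(=O)CN(c1ncnc2c1ncn2C1CCCCO1)C1CC1)C(=O)OCc1ccccc1` differs from compound 2 by isopropyl in place of carbamoylmethyl on a saturated chain carbon bound to an amide-type nitrogen and a carbonyl carbon. Among the compounds with values here, the one step measured so far, a number 15.9 percentage points lower from compound 1 to compound 3 (beyond the scatter), also replaces a group on a saturated chain carbon, but it swaps one polar group for another on the core of compound 1, and the core of compound 2 and compound 4 is different, so it bears only loosely here. Without a closer precedent, the step expected from compound 2 to compound 4 is estimated as a number 3 percentage points lower from compound 2 to compound 4 (within the scatter), not beyond the scatter. Compound 4 is therefore expected at 32%, in the range 15% to 50%.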

Compound 4, a percentage reported as activity, at one dose (the size of the read-out at that dose, not a potency): 30.1%
Compound 4: the middle estimate sits 1.9 percentage points above what was measured; the range from low to high includes it.
By their numbers in this assay, from the lowest: compounds 3, 4, 2 and 1 (each within the scatter of the next, the first and the last beyond it).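

In this assay, isopropyl in place of carbamoylmethyl on the saturated chain carbon bound to an amide-type nitrogen and a carbonyl carbon gives a number 4.9 percentage points lower from compound 2 to compound 4 (within the scatter). On the core of compound 2, this position therefore accepts a group with 0 hydrogen-bond donors and 0 hydrogen-bond acceptors without a step beyond the scatter. No measurement bearing on the reason for this result is available. Still open, on these data alone, is whether a carboxylic acid, an amine or a longer chain at this position on that core would give a step beyond the scatter.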